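Swapping a Urea for a Chlorinated Amide

This account rests on a few compounds, and the source may have more. Where it says the series, first, only, none or still open, it means among the compounds named here.

For the measured compounds named here, compound 2 `COc1cc(-c2nn(-c3cccc(NC(=O)Nc4cccc(C(F)(F)F)c4)c3)cc2-c2ccncc2)ccc1Cl` is the only compound here with a number rather than a limit in a functional assay on Malme-3M cells (Homo sapiens) for inhibition, read by sulforhodamine B assay, with a stated time of 48 h; on this read-out lower numbers stand for higher toxicity in this test and higher numbers for lower toxicity in this test; in this assay compound 2 gives 33900 nM. Compound 1 `COc1cc(-c2nn(-c3cccc(NC(=O)c4cccc(C(F)(F)F)c4)c3)cc2-c2ccncc2)ccc1Cl` is the matching amide. In this assay compound 1 reaches only > 50000 nM, which is a limit of the assay and not a number. Going by the values given here, the one measured step, an at least 1.4-fold lower number from compound 1 to compound 2 (0.16 log units; that floor lies within the scatter), rests on that limit of > 50000 nM in this assay, at which 1 of the 2 values shown sits, and stays within the scatter.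

Compound 3 `COc1cc(-c2nn(-c3cccc(NC(=O)c4ccc(Cl)c(C(F)(F)F)c4)c3)cc2-c2ccncc2)ccc1Cl` is the unmeasured compound: 4-chloro-3-(trifluoromethyl)phenyl in place of (3-(trifluoromethyl)phenyl)amino on a carbonyl carbon. This change returns to an amide like compound 1 and adds a chlorine. Among the compounds with values here, the only step bearing on it is the one between those two compounds; because an at least 1.4-fold lower number from compound 1 to compound 2 (0.16 log units; that floor lies within the scatter) lies within the scatter, the expected step of a 1.5-fold higher number from compound 2 to compound 3 (0.17 log units; within the scatter) is a mild move back toward the limit of compound 1, with no clear shift beyond the scatter. Compound 3 is therefore estimated at 50000 nM, ranging from 22000 nM to 110000 nM.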

Compound 3, concentration lethal to 50% of the cells: > 32500 nM
Compound 3 ended at the assay's limit; the forecaster's own chance of this, stated with the estimate: 50%; the middle value is on the limit's open side.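

The result for compound 3 in this assay is a limit of the assay and not a number, so the steps to it from compound 2 and from compound 1 cannot be read. From the compounds shown here alone, since compound 1 and compound 3 both stand at limits, the effect of chloro in place of hydrogen on an aromatic carbon stays open.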